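Compound 1 to compound 3: one added methoxy

This account rests on a few compounds, and the source may have more. Where it says the series, first, only, none or still open, it means among the compounds named here.

Among the measured compounds shown here, in a functional assay on COLO 205 cells (Homo sapiens) for inhibition, read by sulforhodamine B assay, with a stated time of 48 h, tested at 50 uM (a lower number here means less inhibition of growth, a higher number more inhibition of growth at the concentration tested), compound 1 `COc1ccc(/C=C/C(=O)/C=C/c2ccc(OCc3cn(CCCCOc4cc(=O)oc5ccccc45)nn3)c(OC)c2)cc1OC` gives 53%, the highest of the two numbers available so far. Compound 2 `COc1cc(/C=C/C(=O)/C=C/c2cccs2)ccc1OCc1cn(CCCCCOc2cc(=O)oc3ccccc23)nn1` gives 30%, a gap beyond the usual scatter. Compound 3 `COc1cc(/C=C/C(=O)/C=C/c2cc(OC)c(OC)c(OC)c2)ccc1OCc1cn(CCCCOc2cc(=O)oc3ccccc23)nn1` has not yet been measured. The structural change from compound 1 is methoxy in place of hydrogen on an aromatic carbon, which turns 3,4-dimethoxyphenyl into 3,4,5-trimethoxyphenyl. For the measured compounds named here, no measured pair isolates this change, so the expectation rests only on compound 1 at 53% and carries wide uncertainty. No step beyond the scatter is expected in this assay, and no clear direction can be assigned. The estimated change is small, a number 2 percentage points higher from compound 1 to compound 3 (within the scatter). For compound 3 the expected value is 55%, within an estimated range of 38% to 72%.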

Compound 3, percent growth inhibition at one concentration: 60%
Beside the measured number, compound 3's estimate is 5 percentage points below it, and the stated range covers the measured number.
By their numbers in this assay, from the lowest: compound 2; then compounds 1 and 3 (each within the scatter of the next).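

In this assay, the change from 3,4-dimethoxyphenyl to 3,4,5-trimethoxyphenyl gives the series its first pair that differs in one place: a number 7 percentage points higher from compound 1 to compound 3 (within the scatter). On this pair, the aromatic carbon ortho to a methoxy group and meta to a large group takes methoxy in place of hydrogen with no step beyond the scatter, so this site on the core of compound 1 does not show a sharp response to this one addition at the single concentration tested. No measured data bear on the reason for this result.

As far as these compounds go, whether this position responds differently to an amine, a hydroxyl or a carboxylic acid remains open. Also open, from the compounds shown here alone, is whether the same methoxy step holds when a longer chain stands elsewhere on the shared core.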